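The compounds below may be only part of what the source reports. "The series", "measured", "known", "first", "only" and "open" are said of these compounds alone.

Compound 1 `O=C1c2ccccc2CN1c1cnc(NCc2c(F)ccc3c2CCO3)n2cnnc12` gives 4000 nM in a physicochemical assay for solubility, read by LC-MS, in phosphate buffer, with a stated time of 24 h, at pH 7.4; on this read-out lower numbers stand for lower solubility and higher numbers for higher solubility. Compound 2 `CN(C)Cc1ccc2c(c1)CN(c1cnc(NCc3c(F)ccc4c3CCO4)c3cn[nH]c(=O)c13)C2=O` gives 174000 nM. Compound 3 `Cc1nc(CN(C)C)ccc1-c1cnc(NCc2c(F)ccc3c2CCO3)c2cn[nH]c(=O)c12` gives only a limit of the assay, > 1000000 nM.

Among the two numbers, compound 1 stands lowest, and the gap up to compound 2 lies beyond the usual scatter of repeated measurements. Compound 4 `CN(c1cccnc1)c1cnc(NCc2c(F)ccc3c2CCO3)n2cnnc12` keeps the core of compound 1 and changes a single group: a group of 8 heavy atoms (6 carbon, 2 nitrogen; one six-membered aromatic ring with 1 hetero atom) in place of a group of 10 heavy atoms (8 carbon, 1 nitrogen, 1 oxygen; one five-membered non-aromatic ring with 1 hetero atom, one six-membered aromatic ring of carbon only), on an aromatic carbon. Going by the values given here, no measured pair isolates exactly this change, so the expectation rests on the spread seen across compounds 1, 2 and 3, in which a smaller group at this position went with a higher number. The expected step is a 5.0-fold higher number from compound 1 to compound 4 (0.70 log units; beyond the scatter), upward and beyond the scatter. Compound 4 is expected to reach 20000 nM, with a range from 5000 nM to 80000 nM.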

Compound 4, solubility: 47000 nM
The estimate for compound 4 lay 2.4-fold (0.37 log units) below the measured number; low and high end bracket the measured number.
By their numbers in this assay, from the lowest: compound 1; then compound 4; then compound 2. At a limit, above all of these: compound 3.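

On the shared core, at this aromatic carbon, putting methyl(pyridin-3-yl)amino in place of the group with a five-membered and a six-membered ring gives a 12-fold higher number from compound 1 to compound 4 (1.07 log units; beyond the scatter) in this assay. Going by these compounds alone, the earlier compounds differed from one another in more than one place, so this is the first change at this position that can be read on its own. The compounds shown hold no measurement that explains the size of this step.

From the compounds shown here alone, it remains open how a plain amine or a morpholine at this place would compare. Also open, going by these compounds, is whether the same change would give a similar step on the cores of compound 2 and compound 3.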